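Replacing a Hydroxyazetidine with a Cyanopiperidine

The source may report more compounds than this note shows. Statements on the series, on what has been measured and on what is new or still open speak of the compounds shown alone.

- compound 1 `OCC1CCN(c2cccnc2OC2CN(c3ccc4ccccc4n3)C2)CC1` gives 189000 nM
- compound 2 `OC1CN(c2nccnc2OC2CN(c3ccc4ccccc4n3)C2)C1` gives 41000 nM

In a physicochemical assay for solubility, in phosphate buffer, at pH 7.4 (on this read-out lower numbers stand for lower solubility and higher numbers for higher solubility), compound 2 gives 41000 nM as the lower of the two numbers, and its gap to compound 1 lies beyond the scatter. Within the data shown here, the two differ in more than one place, so no measured step guides what follows. Compound 3 `N#CC1CCN(c2nccnc2OC2CN(c3ccc4ccccc4n3)C2)CC1` carries 4-cyanopiperidin-1-yl in place of 3-hydroxyazetidin-1-yl on an aromatic carbon and awaits measurement. The expected 3.4-fold lower number from compound 2 to compound 3 (0.53 log units; beyond the scatter) is a moderate move to a lower number in this assay and beyond the scatter, though this is tentative. For compound 3 the estimated value is 12000 nM with an expected range from 2500 nM to 50000 nM in this read-out.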

Compound 3, solubility: 66000 nM
For compound 3 the middle estimate is 5.5-fold (0.74 log units) below the measured one; the whole stated range lies below it.
By their numbers in this assay, from the lowest: compounds 2 and 3 (each within the scatter of the next); then compound 1.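

In this assay the step of a 1.6-fold higher number from compound 2 to compound 3 (0.21 log units; within the scatter) comes with 4-cyanopiperidin-1-yl in place of 3-hydroxyazetidin-1-yl on an aromatic carbon next to the ring nitrogen. At this position, a six-membered ring with a nitrile and no hydrogen-bond donor thus reads the same, within the scatter, as a four-membered ring with a hydrogen-bond donor. Nothing at hand explains this result.

Still open, going by these compounds, is whether ring size and the substituent each matter separately, with their effects merely offsetting here. Also open, on these data alone, is how a piperidine bearing an amine or a carboxylic acid in place of the nitrile would read.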